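Hydrazone aryl variation on a shared triazolyl-pyridyl ether core

The source may report more compounds than this note shows. Statements on the series, on what has been measured and on what is new or still open speak of the compounds shown alone.

Measured so far:
compound 1 `CN(C)CCn1cnnc1-c1cc(Oc2ccc(NC(=O)N/N=C/c3c[nH]c4ccccc34)cc2F)ccn1` — 690 nM
compound 2 `CN(C)CCn1cnnc1-c1cc(Oc2ccc(NC(=O)N/N=C/c3ccc(O)cc3O)cc2F)ccn1` — 15400 nM

In a functional assay on U-87MG ATCC cells (Homo sapiens) for cytotoxicity, read by MTT assay, with a stated time of 72 h (a lower number here means a stronger inhibitor, a higher number a weaker inhibitor), compound 2 gives the highest number of the two; its nearest neighbour is compound 1, and the move a 22-fold higher number from compound 1 to compound 2 (1.35 log units; beyond the scatter) is large. Compound 3 `CN(C)CCn1cnnc1-c1cc(Oc2ccc(NC(=O)N/N=C/c3cccc(O)c3)cc2F)ccn1` differs from compound 2 by 3-hydroxyphenyl in place of 2,4-dihydroxyphenyl on a carbon with a double bond to nitrogen. Going by the values given here, no measured step covers this change directly; the only step known swaps the whole aryl group for an indolyl, so it does not bear on a hydroxyl count within a phenyl. For compound 3 a small step, a 1.7-fold lower number from compound 2 to compound 3 (0.23 log units; within the scatter), is expected, likely within the scatter. Compound 3 is estimated at 9000 nM, range 2500 nM to 30000 nM.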

Compound 3, half-maximal inhibitory concentration: > 100000 nM
Compound 3: a limit, no number; the forecaster's own chance of this, stated with the estimate: 10%; middle value at least 11-fold (1.04 log units) away from the limit.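

In this assay, a change within the phenyl alone, with no indolyl swap, is enough to move the reading on the carbon with a double bond to nitrogen: 3-hydroxyphenyl in place of 2,4-dihydroxyphenyl gives an at least 6.4-fold higher number from compound 2 to compound 3 (0.81 log units; beyond the scatter). The hydroxyphenyl groups thus do not read alike, and the distance to the indolyl grows to an at least 140-fold higher number from compound 1 to compound 3 (2.16 log units; beyond the scatter). The reading of compound 3, > 100000 nM, is a limit of the assay and not a number.

Still open, as far as these compounds go, is whether the step follows the number of hydroxyl groups or where they sit on the phenyl. Also open, from the compounds shown here alone, is how a methoxyphenyl or an aminophenyl at this place would read against compound 2 and compound 3.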